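Nitro on the methoxyphenyl ring: ester pair and acid pair

The compounds below may be only part of what the source reports. "The series", "measured", "known", "first", "only" and "open" are said of these compounds alone.

Compound 1 `CCOC(=O)c1cc(-c2cc(OC)c(OC)c(OC)c2)c(-c2ccc(OC)cc2)s1` and compound 2 `CCOC(=O)c1cc(-c2cc(OC)c(OC)c(OC)c2)c(-c2ccc(OC)c([N+](=O)[O-])c2)s1` form one pair; compound 3 `COc1ccc(-c2cc(C(=O)O)sc2-c2cc(OC)c(OC)c(OC)c2)cc1` and compound 4 `COc1ccc(-c2cc(C(=O)O)sc2-c2cc(OC)c(OC)c(OC)c2)cc1[N+](=O)[O-]` form the other, and the difference between the two cores is not broken down here. In a functional assay on KB cells (Homo sapiens) for antiproliferative activity, read by MTT assay, with a stated time of 72 h (a higher number here means a weaker inhibitor, a lower number a stronger inhibitor), compound 1 gives 13200 nM, compound 2 gives 15800 nM and compound 3 gives 8650 nM; all three sit within the scatter of one another. The change from compound 1 to compound 2 is nitro in place of hydrogen on an aromatic carbon, and it made a 1.2-fold higher number from compound 1 to compound 2 (0.08 log units; within the scatter). The change from compound 3 to compound 4 is nitro in place of hydrogen on an aromatic carbon; its place reads the same as in the first pair, so it is the same change on a different core. Resting on a 1.2-fold higher number from compound 1 to compound 2 (0.08 log units; within the scatter), the expected step is a 1.2-fold higher number from compound 3 to compound 4 (0.06 log units; within the scatter). Compound 4 is therefore expected to give about 10000 nM in this assay, estimated between 5000 nM and 20000 nM.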

Compound 4, half-maximal inhibitory concentration: 43700 nM
Compound 4: the middle estimate sits 4.4-fold (0.64 log units) below what was measured; the measured number lies above the stated range.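

On the core of compound 3, nitro in place of hydrogen on an aromatic carbon gave a 5.1-fold higher number from compound 3 to compound 4 (0.70 log units; beyond the scatter) in this assay. The size of this step therefore did not carry over from the core of compound 1: the same change on two cores in this assay, a 1.2-fold higher number (0.08 log units; within the scatter) from compound 1 to compound 2 and a 5.1-fold higher number (0.70 log units; beyond the scatter) from compound 3 to compound 4, 4.2-fold (0.63 log units) apart, beyond the scatter of two such steps. Two pairs show only that the size of the step differs between these two cores; they do not show which difference between the cores goes with it, or what size the step would take on a further core.

Still open, from the compounds shown here alone, is whether an amine or a chlorine, ortho to a methoxy group, would give a step like that of nitro on either core. Also open, going by these compounds, is how the nitro step would read on a core carrying an amide.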